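Swapping a Saturated Ring for an Aromatic One

This account rests on a few compounds, and the source may have more. Where it says the series, first, only, none or still open, it means among the compounds named here.

Compound 1 `Cc1cccc(-c2noc(C3CN(S(=O)(=O)c4ccc(Cl)cc4)C3)n2)c1` gives 1100 nM in an assay on HEK293 cells for negative allosteric modulation of metabotropic glutamate receptor 5 (Homo sapiens), read by FLIPR; a higher number here means a weaker inhibitor, a lower number a stronger inhibitor.
Compound 2 `CC1CCC(C(=O)N2CC(c3nc(-c4cccc(Cl)c4)no3)C2)CC1` gives > 10000 nM in this assay, which is a limit of the assay, not a number.
Compound 3 `O=C(C1CCC(C(F)(F)F)CC1)N1CC(c2nc(-c3cccc(Cl)c3)no2)C1` gives > 10000 nM in this assay, also a limit.

Compound 2 thus sits at the limit of > 10000 nM in this assay, at which 2 of the 3 values shown sit, so only a bound is known for it. Within the data shown here, the one measured step, a step that the two limits leave unreadable from compound 2 to compound 3, cannot be read for the same reason. Compound 4 `O=C(c1ccc(F)cc1)N1CC(c2nc(-c3cccc(Cl)c3)no2)C1` differs from compound 2 by 4-fluorophenyl in place of 4-methylcyclohexyl on a carbonyl carbon. Among the measured compounds shown here, no measured step bears on this change; compound 1, the only compound with a number, carries its aromatic ring on a different linker. The step of an at least 1.6-fold lower number from compound 2 to compound 4 (0.22 log units; that floor lies within the scatter) is estimated only loosely. Compound 4 is expected at 6000 nM, within 1500 nM to 20000 nM, with a real chance that only a limit is reported again.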

Compound 4, half-maximal inhibitory concentration: 4000 nM
For compound 4 the middle estimate is 1.5-fold (0.18 log units) above the measured one, and the stated range covers the measured number.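

Replacing 4-methylcyclohexyl with 4-fluorophenyl on the carbonyl carbon brings an at least 2.5-fold lower number from compound 2 to compound 4 (0.39 log units; beyond the scatter) in this assay. This shows that the group at this position can move the result beyond the scatter, and that an aromatic ring here can give a readable number. The step is only a floor because compound 2 carries a limit: the limit of > 10000 nM in this assay, at which 2 of the 4 values shown sit.

On these data alone, it remains open whether the ring itself or its fluorine accounts for the step. A plain phenyl group on the same carbonyl carbon would separate the two.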